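The compounds below may be only part of what the source reports. "The series", "measured", "known", "first", "only" and "open" are said of these compounds alone.

In a physicochemical assay for lipophilicity, at pH 7.4 (on this read-out lower numbers stand for lower lipophilicity and higher numbers for higher lipophilicity), two compounds built on a shared core have been measured so far. Compound 1 `CNC(=O)c1cc(C(=O)NC2CC2)cn(Cc2cccc3[nH]c(C)nc23)c1=O` gives 1.5, and compound 2 `CNC(=O)c1cc(C(=O)NC2CC2)cn(Cc2cccc3[nH]ccc23)c1=O` gives 2.9, which is the higher of the two numbers and lies beyond the usual scatter of repeated measurements. Compound 3 `CNC(=O)c1cc(C(=O)NC2CC2)cn(Cc2cccc3[nH]ncc23)c1=O` has not yet been measured. It differs from compound 2 in one place, with 1H-indazol-4-yl in place of 1H-indol-4-yl on a saturated chain carbon bound to an aromatic nitrogen. Within the data shown here, no measured pair of compounds shows this exact swap, so any forecast is rough. Compound 1, at 1.5, does show that a compound on this core can read well lower than compound 2. A moderate downward move beyond the scatter is expected, with an estimated a number 0.60 log units lower from compound 2 to compound 3 (beyond the scatter). For compound 3 the expected value in this assay is 2.3, with an estimated range from 1.9 to 2.7.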

Compound 3, distribution coefficient: 1.5
The estimate for compound 3 lay 0.80 log units above the measured number; the whole stated range lies above it.
By their numbers in this assay, from the lowest: compounds 1 and 3 (each within the scatter of the next); then compound 2.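

Read in this assay, the shared core now has its first step at a single place: a number 1.40 log units lower from compound 2 to compound 3 (beyond the scatter) with 1H-indazol-4-yl in place of 1H-indol-4-yl on a saturated chain carbon bound to an aromatic nitrogen. The two groups have the same number of heavy atoms and the same hydrogen-bond donor count, and differ only in a nitrogen standing for a carbon and in the hydrogen-bond acceptor counted for the entering group, so a small change in atoms at this place can carry a large step. Nothing among the data explains why the step is this large.

Going by these compounds, how an amine or a carboxylic acid in place of 1H-indazol-4-yl would read in this assay stays open. On these data alone, whether the same swap gives a similar step on a different core also stays open.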